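Ring-nitrogen substituent change in the ethoxyphenyl series

The compounds below may be only part of what the source reports. "The series", "measured", "known", "first", "only" and "open" are said of these compounds alone.

Three compounds have numbers in a functional assay on PANC-1 cells (Homo sapiens) for cytotoxicity, read by resazurin assay, with a stated time of 48 h; a lower number here means a stronger inhibitor, a higher number a weaker inhibitor. Compound 1 `CCN/C(SC)=C(/C#N)C(=O)Nc1ccc(OCC)cc1` gives 41600 nM, compound 3 `C=CCN/C(SC)=C(/C#N)C(=O)Nc1ccc(OCC)cc1` gives 21800 nM, and compound 2 `CCOc1ccc(-n2nnc3n[nH]c(NC)c3c2=O)cc1` gives 9920 nM. Compound 2 stands lowest of the three, with compound 3 nearest and compound 1 furthest, both gaps beyond the scatter. For the measured compounds named here, the one step between measured compounds that differ in one place, a 1.9-fold lower number from compound 1 to compound 3 (0.28 log units; within the scatter), concerns vinyl in place of methyl on a saturated chain carbon bound to an amine nitrogen and sits on the other core, so it does not bear directly on the change now considered.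

Compound 4 `CCOc1ccc(-n2nnc3n[nH]c(Nc4ccccc4)c3c2=O)cc1` differs from compound 2 by phenyl in place of methyl on a nitrogen on an aromatic ring. Going by the values given here, no measured step addresses this change on the core of compound 2, so the expectation rests on the small, within-scatter effect of the only chain extension seen and on the absence of any counter-example. The step from compound 2 to compound 4 is estimated as a 1.2-fold lower number from compound 2 to compound 4 (0.09 log units; within the scatter) in this assay, with no strong direction. For compound 4 the estimate in this assay is 8000 nM, within a range of 2500 nM to 25000 nM.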

Compound 4, half-maximal inhibitory concentration: 13100 nM
For compound 4 the middle estimate is 1.6-fold (0.21 log units) below the measured one; measured number inside the range.
By their numbers in this assay, from the lowest: compounds 2, 4, 3 and 1 (each within the scatter of the next, the first and the last beyond it).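

For the compounds shown here, on the core of compound 2, phenyl in place of methyl on a nitrogen on an aromatic ring gives a 1.3-fold higher number from compound 2 to compound 4 (0.12 log units; within the scatter) in this assay, the first reading at this position. Methylamino and anilino are thus not told apart here: exchanging the methyl for a six-membered aromatic ring of carbon only produces no step beyond the scatter on this core. No measured evidence speaks to why the two groups read alike.

What a free amine or a benzyl group on this core would give remains open, since only methylamino and anilino are shown here. Also open, from the compounds shown here alone, is whether a phenyl carrying a methoxy group or a carboxylic acid would read like the unsubstituted anilino of compound 4.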